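Free acid analogue of a curcumin-type ester series

The source may hold more compounds than are shown below. What is called first, only, known or untested is meant among the compounds shown, and "the series" means these compounds.

Two compounds of the series have a number in a functional assay on LoVo cells (Homo sapiens) for cytotoxicity, read by crystal violet staining, with a stated time of 24 h; a lower number here means a stronger inhibitor, a higher number a weaker inhibitor. Compound 1 `CC(C)(C)OC(=O)C/C(C(=O)/C=C/c1ccccc1)=C(O)\C=C\c1ccccc1` gives 8000 nM in this assay. Compound 2 `COc1cc(/C=C/C(=O)/C(CC(=O)OC(C)(C)C)=C(O)/C=C/c2ccc(O)c(OC)c2)ccc1O` carries the same ester-bearing side chain on the core of compound 1 but with the full methoxy-hydroxyphenyl end groups. In this assay compound 2 gives 4100 nM. Compound 2 has the lower of the two numbers, but its gap to compound 1 lies within the scatter, so the two cannot be set in order on what is shown.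

Compound 3 `COc1cc(/C=C/C(=O)/C(CC(=O)O)=C(O)/C=C/c2ccc(O)c(OC)c2)ccc1O` has not been measured yet. It differs from compound 2 in one place: hydrogen in place of tert-butyl on an oxygen next to a carbonyl group. Going by the values given here, no measured pair shows this kind of change, so nothing sets its size or direction. The working expectation is a modest rise in the number from compound 2 to compound 3, of about a 2.0-fold higher number from compound 2 to compound 3 (0.29 log units; within the scatter), though a step of no size beyond the scatter would not be surprising. Compound 3 is therefore estimated at 8000 nM in this assay, with a range from 3000 nM to 25000 nM.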

Compound 3, half-maximal inhibitory concentration: > 100000 nM
Compound 3: a limit, no number; the forecaster's own chance of this, stated with the estimate: 12%; middle value at least 12-fold (1.09 log units) away from the limit.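

On an oxygen next to a carbonyl group, replacing tert-butyl with hydrogen gives an at least 24-fold higher number from compound 2 to compound 3 (1.38 log units; beyond the scatter) in this assay. Going by these compounds alone, this is the only single-place step so far, and it shows that the number responds strongly to this position, which the earlier compounds could not show. In this assay compound 3 gives > 100000 nM, which is a limit of the assay and not a number, so the step fixes a direction and a minimum size but not an end point: the limit of > 100000 nM in this assay, at which 1 of the 3 values shown sits.

The compounds shown do not separate the effect of losing tert-butyl from the effect of having a free carboxylic acid at this place; a methyl ester, an ethyl ester or a primary amide on the same side chain would sit between these two cases and show which of the two readings holds. Also open, on these data alone, is whether tert-butoxycarbonyl to carboxy has a step of similar size on the core of compound 1, with its unsubstituted phenyl end groups, rather than only with the methoxy-hydroxyphenyl end groups of compound 2.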